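The source may hold more compounds than are shown below. What is called first, only, known or untested is meant among the compounds shown, and "the series" means these compounds.

Three compounds have been measured in an assay on a protein complex for inhibition of CDK8/Cyclin C (Homo sapiens), with a stated time of 1 h, tested at 10 uM; a higher number here means more inhibition at the concentration tested (going by the name of the read-out), a lower number less inhibition:
compound 1, `CNC(=O)/C=C/c1ccncc1-c1ccc2cc[nH]c2c1`, gives 103%;
compound 2, `O=C(/C=C/c1ccncc1-c1ccc2cc[nH]c2c1)N1CCOCC1`, gives 102%;
compound 3, `CNC(=O)/C=C/c1ccncc1-c1ccc2cnn(C)c2c1`, gives 99%.

All three numbers lie within the usual scatter of one another, so none of them can be called stronger or weaker than the others. Compound 1 and compound 2 share a core and differ by a single change, (morpholin-4-yl in place of methylamino on a carbonyl carbon). This change made a step of a number 1 percentage points lower from compound 1 to compound 2 (within the scatter). The core of compound 3 is not the same as the core of compound 1, and how the two cores differ is not broken down here. Compound 4, `Cn1ncc2ccc(-c3cnccc3/C=C/C(=O)N3CCOCC3)cc21`, has not yet been measured. It arises from compound 3 by morpholin-4-yl in place of methylamino on a carbonyl carbon. The place of this change is described in exactly the same words as for the earlier pair, so it counts as the same change, now made on the core of compound 3. Compound 4 is expected to show a step of a number 1 percentage points lower from compound 3 to compound 4 (within the scatter) because the same change earlier gave a number 1 percentage points lower from compound 1 to compound 2 (within the scatter). Compound 4 is therefore estimated to give about 98%, most likely between 88% and 105%.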

Compound 4, a percentage reported as inhibition, at one concentration (the size of the read-out at that concentration, not a potency): 89%
The estimate for compound 4 lay 9 percentage points above the measured number; measured number inside the range.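

In this assay, putting morpholin-4-yl in place of methylamino on a carbonyl carbon of the core of compound 3 gives a step of a number 10 percentage points lower from compound 3 to compound 4 (within the scatter). Set beside the earlier step on the core of compound 1, the new step cannot be told apart from it: the same change on two cores in this assay, a number 1 percentage points lower (within the scatter) from compound 1 to compound 2 and a number 10 percentage points lower (within the scatter) from compound 3 to compound 4, 9 percentage points apart, within the scatter of two such steps So in these two pairs, the change can be carried from one core to the other without any step beyond the scatter, but this does not prove that its size is the same on both cores, and two pairs say nothing about any further core.

The compounds shown leave open what other groups would give on the same carbonyl carbon, for example dimethylamino, piperidin-1-yl or a longer chain such as 2-methoxyethylamino. They also leave open how compounds 1 to 4 would compare as true potencies, since a reading at one concentration gives only the size of the inhibition there.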